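This account rests on a few compounds, and the source may have more. Where it says the series, first, only, none or still open, it means among the compounds named here.

Working notes on the series. Compound 1 `COc1ncnc2c1c(-c1cccs1)cn2[C@@H]1O[C@H](CO)[C@@H](O)[C@H]1O` gives 4850 nM in a functional assay on A549 cells (Homo sapiens), read by MTT assay, with a stated time of 72 h; a higher number here means a weaker inhibitor, a lower number a stronger inhibitor. Compound 2 `CSc1ncnc2c1c(-c1cccs1)cn2[C@@H]1O[C@H](CO)[C@@H](O)[C@H]1O` reaches only the assay limit, > 20000 nM in this assay, so that value is a limit and not a number. the limit of > 20000 nM in this assay, at which 1 of the 3 values shown sits, applies to compound 2 alone. The change from compound 1 to compound 2 is methylsulfanyl in place of methoxy on an aromatic carbon and it produces an at least 4.1-fold higher number from compound 1 to compound 2 (0.61 log units; beyond the scatter). Compound 3 `C#Cc1cn([C@@H]2O[C@H](CO)[C@@H](O)[C@H]2O)c2ncnc(OC)c12` gives 8160 nM in this assay. The cores of compound 1 and compound 3 differ by ethynyl in place of thiophen-2-yl on an aromatic carbon, a difference that gives a 1.7-fold higher number from compound 1 to compound 3 (0.23 log units; within the scatter). Compound 4 `C#Cc1cn([C@@H]2O[C@H](CO)[C@@H](O)[C@H]2O)c2ncnc(SC)c12` carries, relative to compound 3, the change (methylsulfanyl in place of methoxy on an aromatic carbon), the same change as made from compound 1 to compound 2, at a place described in identical words. For compound 4 a step of a 4.3-fold higher number from compound 3 to compound 4 (0.63 log units; beyond the scatter) in this assay is expected, resting on an at least 4.1-fold higher number from compound 1 to compound 2 (0.61 log units; beyond the scatter). Compound 4 is therefore estimated at 35000 nM, between 15000 nM and 100000 nM, most likely recorded as a limit.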

Compound 4, half-maximal inhibitory concentration: 140 nM
For compound 4 the middle estimate is 250-fold (2.40 log units) above the measured one, outside the stated range (below it).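

In this assay, methylsulfanyl in place of methoxy gives a 58-fold lower number from compound 3 to compound 4 (1.77 log units; beyond the scatter), so on the core carrying ethynyl the change runs opposite to its direction on the core carrying thiophen-2-yl, and its effect does not carry from one core to the other: the same change on two cores in this assay, an at least 4.1-fold higher number (0.61 log units; beyond the scatter) from compound 1 to compound 2 and a 58-fold lower number (1.77 log units; beyond the scatter) from compound 3 to compound 4, at least 240-fold (2.38 log units) apart, beyond the scatter of two such steps

Ethynyl in place of thiophen-2-yl likewise depends on the neighbouring group, giving an at least 140-fold lower number from compound 2 to compound 4 (2.15 log units; beyond the scatter) with methylsulfanyl present, unlike the step with methoxy present: the same change on two cores in this assay, a 1.7-fold higher number (0.23 log units; within the scatter) from compound 1 to compound 3 and an at least 140-fold lower number (2.15 log units; beyond the scatter) from compound 2 to compound 4, at least 240-fold (2.38 log units) apart, beyond the scatter of two such steps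

Compound 2 stands at > 20000 nM, a limit and not a number, and these four compounds show that the two changes do not combine additively, but not why, nor whether this holds beyond them.

The compounds shown leave open whether the low number of compound 4 is particular to this pairing of groups. A propynyl chain in place of ethynyl, or an amine in place of methylsulfanyl, would bear on that.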